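The compounds below may be only part of what the source reports. "The series", "measured", "known", "first", "only" and "open" are said of these compounds alone.

Series notes. Compound 1 `CCCCCCCCS(=O)(=O)Nc1ccc(-c2ccc(-c3ccccc3)cc2)cc1C(=O)O` and compound 2 `CCCCCCCCS(=O)(=O)Nc1ccc(-c2ccc(OC)cc2)cc1C(=O)O` share the same core and differ only in the group on the distal aromatic ring. In an assay on mitochondria (strain BALB/c) for inhibition of glycerol-3-phosphate acyltransferase 1, mitochondrial (Mus musculus), read by scintillation counting, with a stated time of 10 min (a higher number here means a weaker inhibitor, a lower number a stronger inhibitor), compound 1 gives 29100 nM, and compound 2 gives 19500 nM. The change from phenyl to methoxy yields a 1.5-fold lower number from compound 1 to compound 2 (0.17 log units; within the scatter), so the two numbers cannot be ordered. Compound 2 thus stands at the lower of the two numbers available, but only within the scatter of compound 1.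

Compound 3 `CCCCCCCCS(=O)(=O)Nc1ccc(-c2ccc(O)cc2)cc1C(=O)O` carries the next change: hydrogen in place of methyl on an oxygen on an aromatic ring. For the measured compounds named here, no measured step cuts the methyl from an oxygen; the only step recorded, the phenyl to methoxy swap of compound 1 to compound 2, stayed within the scatter. Going by the values given here, with no precedent pointing either way, the expected step is a 1.1-fold lower number from compound 2 to compound 3 (0.06 log units; within the scatter), that is none beyond the scatter. Compound 3 is therefore estimated at 17000 nM, with a range from 6000 nM to 50000 nM.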

Compound 3, half-maximal inhibitory concentration: 47300 nM
Compound 3: middle estimate off by 2.8-fold (0.44 log units), on the low side; low and high end bracket the measured number.
By their numbers in this assay, from the lowest: compounds 2, 1 and 3 (each within the scatter of the next, the first and the last beyond it).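

In this assay, for the compounds shown here, the loss of the methyl from the oxygen on an aromatic ring gives a 2.4-fold higher number from compound 2 to compound 3 (0.38 log units; beyond the scatter) and is the first step beyond the scatter, so this place does register a change as small as methoxy to hydroxy. The step is modest, and hydroxy does not separate from phenyl: the step of a 1.6-fold higher number from compound 1 to compound 3 (0.21 log units; within the scatter) leaves those two compounds unordered, so the only gap that can be read lies between the methoxy and hydroxy compounds. Nothing at hand explains this gap.

As far as these compounds go, whether the gap follows the free hydroxy or the methyl stays open, and an ethoxy or an amine on the same aromatic carbon would bear on that. From the compounds shown here alone, how far any group here can move the numbers also stays open, with the shared core unchanged throughout.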